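The source may report more compounds than this note shows. Statements on the series, on what has been measured and on what is new or still open speak of the compounds shown alone.

In a functional assay on A-375 cells (Homo sapiens) for antiproliferative activity, read by MTT assay, with a stated time of 24 h (on this read-out lower numbers stand for stronger inhibition and higher numbers for weaker inhibition), compound 1 `COc1cc(OC)c(-c2coc3cc(OCC=C(C)C)ccc3c2=O)cc1OC` gives 1580 nM and compound 2 `COc1cc(OC)c(-c2coc3cc(OCc4ccc(C#N)cc4)ccc3c2=O)cc1OC` gives 1550 nM. These two values lie within the scatter of each other, so compound 2 stands level with compound 1. Compound 3 `COc1cc(OC)c(-c2coc3cc(OCc4ccccc4Cl)ccc3c2=O)cc1OC` differs from compound 2 in one place: 2-chlorophenyl in place of 4-cyanophenyl on a saturated chain carbon bound to an oxygen on an aromatic ring. Put simply, 2-chlorophenyl takes the place of 4-cyanophenyl on a saturated chain carbon bound to an oxygen on an aromatic ring. For the measured compounds named here, only one measured step bears on this place: a 1.0-fold lower number from compound 1 to compound 2 (0.01 log units; within the scatter). That swap of 4-cyanophenyl for 2-methylprop-1-en-1-yl left the number within the scatter. Going by the values given here, no measured compound carries 2-chlorophenyl, so this evidence is thin, and no step beyond the scatter is expected in this assay. The expected step is a 1.0-fold lower number from compound 2 to compound 3 (0.01 log units; within the scatter). For compound 3, the estimated value is 1500 nM, with an expected range from 700 nM to 3200 nM.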

Compound 3, half-maximal inhibitory concentration: 2020 nM
Estimate against measurement, compound 3: 1.3-fold (0.13 log units) below, within the range that was stated.
By their numbers in this assay, from the lowest: compounds 2, 1 and 3 (each within the scatter of the next).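

In this assay this place, on a saturated chain carbon bound to an oxygen on an aromatic ring, now holds a third group, and 2-chlorophenyl for 4-cyanophenyl gives a 1.3-fold higher number from compound 2 to compound 3 (0.12 log units; within the scatter). Against the open-chain group the picture is the same, with 2-chlorophenyl for 2-methylprop-1-en-1-yl giving a 1.3-fold higher number from compound 1 to compound 3 (0.11 log units; within the scatter). All three groups therefore stand level here, so a ring with chlorine, a ring with a nitrile and a chain without a ring cannot be told apart on this read-out, and nothing measured explains this.

Still open, on these data alone, is whether the level picture holds for a different kind of group at this place, such as an amine or a carboxylic acid. As far as these compounds go, a longer chain in place of 2-methylprop-1-en-1-yl is equally open.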